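The compounds below may be only part of what the source reports. "The series", "measured", "known", "first", "only" and "open" are said of these compounds alone.

Series notes, HeLa cytotoxicity.

Compound 1 `N#Cc1c(-c2ccccc2)c(C#N)c(=O)n(/N=C/c2cn(-c3ccccc3)nc2-c2ccccc2)c1N`: in an ADME assay on HeLa cells (Homo sapiens) for cytotoxicity, read by MTT assay (on this read-out higher numbers stand for weaker inhibition and lower numbers for stronger inhibition), compound 1 gives > 200 ug/mL, a limit of the assay.
Compound 2 `N#Cc1c(-c2ccc(O)cc2)c(C#N)c(=O)n(/N=C/c2cn(-c3ccccc3)nc2-c2ccccc2)c1N`: in this assay compound 2 gives > 200 ug/mL, also a limit.
Compound 3 `N#Cc1c(-c2ccc(Cl)cc2)c(C#N)c(=O)n(/N=C/c2cn(-c3ccccc3)nc2-c2ccccc2)c1N`: in this assay compound 3 gives > 200 ug/mL, again a limit.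

Compound 3 therefore stands at the limit of > 200 ug/mL in this assay, at which 3 of the 3 values shown sit, with both other measured compounds sitting at the same limit. The steps a step that the two limits leave unreadable from compound 1 to compound 3, a step that the two limits leave unreadable from compound 2 to compound 3 and a step that the two limits leave unreadable from compound 1 to compound 2 thus give no readable size.

Compound 4 `COc1ccc(-c2c(C#N)c(N)n(/N=C/c3cn(-c4ccccc4)nc3-c3ccccc3)c(=O)c2C#N)cc1` differs from compound 3 by methoxy in place of chloro on an aromatic carbon. Among the compounds with values here, the only steps that bear on this change are those into compound 3, and none of them yields a size. Compound 4 is accordingly expected to remain at the limit in this assay, so the step that the limit leaves unreadable from compound 3 to compound 4 is estimated as none beyond the scatter. The estimate for compound 4 is 300 ug/mL, in the range 150 ug/mL to 1000 ug/mL.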

Compound 4, half-maximal inhibitory concentration: > 200 ug/mL
Compound 4 ended at the assay's limit (the forecaster's own chance of this, stated with the estimate: 85%); the middle value does not contradict the limit.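

No step from compound 1, compound 2 or compound 3 to compound 4 can be read: the limit of > 200 ug/mL in this assay, at which 4 of the 4 values shown sit.

The compounds shown leave open how far each lies past that limit, and so whether any of these changes on the phenyl ring alters the read-out in this assay.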